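The source may hold more compounds than are shown below. What is called first, only, known or untested is meant among the compounds shown, and "the series" means these compounds.

Measured compounds:
compound 1 `O=C(Nc1ccc(Oc2ccnc3[nH]ccc23)c(F)c1)c1cn(-c2ccc(F)cc2)c2ccccc2c1=O`: 270 nM
compound 2 `O=C(Nc1ccc(Oc2ccnc3[nH]ccc23)c(F)c1)c1cn(-c2ccc(Cl)cc2)c2ccccc2c1=O`: 380 nM

In a functional assay on HepG2 cells (Homo sapiens) for inhibition, read by MTT assay, with a stated time of 72 h (a lower number here means a stronger inhibitor, a higher number a weaker inhibitor), compound 1 gives 270 nM and compound 2 gives 380 nM. For the measured compounds named here, compound 2 holds the higher of the two numbers, but its only neighbour is compound 1, and the step of a 1.4-fold higher number from compound 1 to compound 2 (0.15 log units; within the scatter) lies within the scatter, so the two compounds cannot be told apart on these numbers.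

Compound 3 `O=C(Nc1ccc(Oc2ccnc3[nH]ccc23)c(F)c1)c1cn(-c2ccc(Br)cc2F)c2ccccc2c1=O` is the next compound in this account. Relative to compound 2 the change is 4-bromo-2-fluorophenyl in place of 4-chlorophenyl on an aromatic nitrogen. Going by the values given here, the only measured step that bears on it is the exchange of one halogen for another on the same ring, a 1.4-fold higher number from compound 1 to compound 2 (0.15 log units; within the scatter), which was small. Among the compounds with values here, the second part of the change, the added fluorine on the entering ring, has no measured counterpart here, and nothing in the two measured compounds speaks for or against it. The expectation is therefore a step of no clear size beyond the scatter, with a wide range to allow for the untested part. Compound 3 is expected to give about 400 nM in this assay. The range for compound 3 is estimated from 180 nM to 900 nM. That amounts to an expected step of a 1.1-fold higher number from compound 2 to compound 3 (0.02 log units; within the scatter).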

Compound 3, half-maximal inhibitory concentration: 2200 nM
For compound 3 the middle estimate is 5.5-fold (0.74 log units) below the measured one; the measured number lies above the stated range.
By their numbers in this assay, from the lowest: compounds 1 and 2 (each within the scatter of the next); then compound 3.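

In this assay the group on the aromatic nitrogen proves sensitive to change: the earlier exchange of fluoro for chloro stayed within the scatter, but 4-bromo-2-fluorophenyl in place of 4-chlorophenyl gives a 5.8-fold higher number from compound 2 to compound 3 (0.76 log units; beyond the scatter) and 4-bromo-2-fluorophenyl in place of 4-fluorophenyl gives an 8.1-fold higher number from compound 1 to compound 3 (0.91 log units; beyond the scatter) in the direction of a weaker inhibitor. For the compounds shown here, these are the first steps at this position that lie beyond the scatter, so the halogen pair alone had understated how much the number can move here. The change holds two edits at once, a bromine where the earlier compounds carry another halogen and an added fluorine on the same ring, and no evidence is available to account for the weaker number.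

The compounds shown do not tell whether the bromine alone or the added fluorine alone carries the step, and a ring with just one of the two would be needed to separate them. Going by these compounds, it also remains open how the number would respond to an amine or a carboxylic acid on that ring, or to a simple methyl on the nitrogen in place of the ring.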